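From hydroxy to amino: compound 3 to compound 4

This account rests on a few compounds, and the source may have more. Where it says the series, first, only, none or still open, it means among the compounds named here.

Compound 1 `CSc1ccc(NC(=O)Nc2cc(C)nc3ccccc23)cc1`: 16000 nM
Compound 2 `Cc1cc(NC(=O)Nc2ccc(F)cc2)c2ccccc2n1`: > 25000 nM (a limit)
Compound 3 `Cc1cc(NC(=O)Nc2ccc(O)cc2)c2ccccc2n1`: > 25000 nM (a limit)

In an ADME assay on HepG2 cells (Homo sapiens) for cytotoxicity, with a stated time of 72 h (a lower number here means that less compound is needed, a higher number that more compound is needed for the effect), only compound 1 has a true number, 16000 nM. Compound 2 gives > 25000 nM, which is a limit. Going by these compounds, compound 3 gives > 25000 nM, which is also a limit, so it stands on the limit of > 25000 nM in this assay, at which 2 of the 3 values shown sit, and its true position is unknown.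

Compound 4 `Cc1cc(NC(=O)Nc2ccc(N)cc2)c2ccccc2n1` carries amino in place of hydroxy on an aromatic carbon.

Among the compounds with values here, no measured step involves amino, so the evidence is indirect. Replacing methylsulfanyl gave an at least 1.5-fold higher number from compound 1 to compound 2 (0.19 log units; that floor lies within the scatter) with fluoro and an at least 1.5-fold higher number from compound 1 to compound 3 (0.19 log units; that floor lies within the scatter) with hydroxy. The nearest comparison, a swap between two small groups in the same place, gave a step that the two limits leave unreadable from compound 2 to compound 3. Together these steps show no change beyond the scatter, so no clear step in either direction is expected in this assay. Within the data shown here, the range stays wide, and it reaches down past the one true number, since the limits hide how far these compounds really lie.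

The expected result is a number no higher from compound 3 to compound 4 (the limit leaves the size open). For compound 4 the estimated value is 25000 nM, with an expected range from 10000 nM to 50000 nM.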

Compound 4, half-maximal effective concentration: > 25000 nM
Compound 4 was reported as a limit; the forecaster's own chance of this, stated with the estimate: 60%; the middle value sits exactly at the limit.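

In this assay, compound 4 is one more compound reported as a limit rather than a true number, so amino now stands with fluoro and hydroxy at this place on the aromatic ring, and the limit holds most of the series: the limit of > 25000 nM in this assay, at which 3 of the 4 values shown sit. The steps that link compound 4 to compound 2 and to compound 3 cannot be read, as both ends of each step are limits. Within the data shown here, the one step that can be read is an at least 1.5-fold higher number from compound 1 to compound 4 (0.19 log units; that floor lies within the scatter), so compound 1, with methylsulfanyl, remains the only compound here with a true number, and this step does not establish a real difference.

The compounds shown leave open how far past the limit compound 2, compound 3 and compound 4 truly lie, and whether these three differ from one another at all. They also leave open what other groups at this place would give, such as a carboxylic acid, a methoxy group or a longer chain like ethylsulfanyl, and so whether methylsulfanyl really stands apart.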